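Adding a methoxy to the benzoyl of compound 3

This account rests on a few compounds, and the source may have more. Where it says the series, first, only, none or still open, it means among the compounds named here.

Compound 1 `COc1ccc(-n2c(SC)nnc2-c2cc(OC)c(OC)c(OC)c2)cc1` gives > 60000 nM as a limit
Compound 2 `COc1ccc(CSc2nnc(-c3cc(OC)c(OC)c(OC)c3)n2-c2ccc(OC)cc2)cc1` gives 40300 nM as a measured number
Compound 3 `COc1ccc(-n2c(SCC(=O)c3ccccc3)nnc2-c2cc(OC)c(OC)c(OC)c2)cc1` gives > 60000 nM as a limit

In a functional assay on PC-3 cells (Homo sapiens) for inhibition, read by MTT assay, with a stated time of 48 h (a lower number here means a stronger inhibitor, a higher number a weaker inhibitor), the three compounds share one core and differ only in the group on the chain carbon bound to sulfur. For compound 3 the reading is the limit of > 60000 nM in this assay, at which 2 of the 3 values shown sit, with no exact number behind it.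

Compound 4 `COc1ccc(C(=O)CSc2nnc(-c3cc(OC)c(OC)c(OC)c3)n2-c2ccc(OC)cc2)cc1` is compound 3 with one change methoxy in place of hydrogen on an aromatic carbon in which benzoyl becomes (4-methoxyphenyl)carbonyl. Among the compounds with values here, no measured step tests this change directly, so the evidence is indirect. The chain change gave an at least 1.4-fold lower number from compound 1 to compound 2 (0.17 log units; that floor lies within the scatter) and the swap to benzoyl gave an at least 1.4-fold higher number from compound 2 to compound 3 (0.17 log units; that floor lies within the scatter) and both of these floors lie within the scatter. Benzoyl on the bare chain gave a step that the two limits leave unreadable from compound 1 to compound 3 and so adds nothing.

The estimated change is an at least 1.2-fold lower number from compound 3 to compound 4 (0.07 log units; that floor lies within the scatter) and no shift beyond the scatter is expected. For compound 4 the estimate in this assay is 50000 nM with an expected range from 20000 nM to 100000 nM and another bare limit is quite possible.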

Compound 4, half-maximal inhibitory concentration: > 60000 nM
Compound 4: only a limit was reported (the forecaster's own chance of this, stated with the estimate: 60%); at least 1.2-fold (0.07 log units) between middle value and limit.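

Compound 4 stands at a limit and not at an exact number, as compounds 1 and 3 do: the limit of > 60000 nM in this assay, at which 3 of the 4 values shown sit. Going by these compounds, the steps that join two limits cannot be read, so what the methoxy does on the aromatic carbon stays unknown, and adding it to the benzoyl gives no exact number in this assay. Within the data shown here, the one readable step is an at least 1.4-fold higher number from compound 2 to compound 4 (0.17 log units; that floor lies within the scatter), so this floor does not separate compound 4 from compound 2, which remains the only compound here with an exact number.

Still open, on these data alone, is whether an amine or a carboxylic acid at that same place on the ring would give an exact number. Also open, as far as these compounds go, is whether a longer chain on the sulfur would do so.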